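This account rests on a few compounds, and the source may have more. Where it says the series, first, only, none or still open, it means among the compounds named here.

Among the measured compounds shown here, in a functional assay on OCI-Ly3 cells (Homo sapiens) for antiproliferative activity (a lower number here means that less compound is needed, a higher number that more compound is needed for the effect), compound 1 `O=C(Nc1cnc(-n2nccn2)c(Cl)c1)Nc1cnc2ccc(Cl)cc2c1C1CC1` gives 990 nM and compound 2 `O=C(Nc1cnc(-n2nccn2)c(Cl)c1)Nc1cnc2ccc(F)cc2c1C1CC1` gives 720 nM, so compound 2 stands level with its only neighbour once the usual scatter is allowed for. Compound 3 `COc1ccc2ncc(NC(=O)Nc3cnc(-n4nccn4)c(Cl)c3)c(C3CC3)c2c1` has methoxy in place of fluoro on an aromatic carbon. For the measured compounds named here, the one measured step at this place, a 1.4-fold lower number from compound 1 to compound 2 (0.14 log units; within the scatter), exchanged one halogen for another, so it is only a weak guide to methoxy. No shift beyond the scatter is expected in this assay, and the estimated step is a 1.0-fold lower number from compound 2 to compound 3 (0.01 log units; within the scatter). For compound 3 the expected value is 700 nM, with an estimated range of 250 nM to 2000 nM.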

Compound 3, half-maximal effective concentration: 2390 nM
Estimate against measurement, compound 3: 3.4-fold (0.53 log units) below; measured number above the stated range.
By their numbers in this assay, from the lowest: compounds 2 and 1 (each within the scatter of the next); then compound 3.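

In this assay, this position proved sensitive to more than a swap between halogens: methoxy gives a 3.3-fold higher number from compound 2 to compound 3 (0.52 log units; beyond the scatter) and also a 2.4-fold higher number from compound 1 to compound 3 (0.38 log units; beyond the scatter), and both steps lie beyond the scatter. Methoxy is thus the first change here to move the number clearly, and it moves it upward, while the exchange of chloro for fluoro did not. Nothing available explains this shift. Still open, from the compounds shown here alone, is whether a hydroxyl, an amine or a longer ether chain here would raise the number further or bring it back down.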